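Pyranone series: acetyl side chain at the isopropyl position

The source may hold more compounds than are shown below. What is called first, only, known or untested is meant among the compounds shown, and "the series" means these compounds.

Compound 3 `Cc1c(O)cc(CCCC(C)C)oc1=O` stands in a functional assay on NCI-H460 cells (Homo sapiens) for cytotoxicity, read by MTT assay (on this read-out lower numbers stand for stronger inhibition and higher numbers for weaker inhibition), only at a limit, giving > 200000 nM. Compound 1 `Cc1c(O)cc(CCCCC(C)[C@H](C)O)oc1=O` also returns a limit in this assay, > 200000 nM. Compound 2 `CCC(C)CCCCc1cc(O)c(C)c(=O)o1` likewise sits at a limit, > 200000 nM. The steps a step that the two limits leave unreadable from compound 1 to compound 2, a step that the two limits leave unreadable from compound 1 to compound 3 and a step that the two limits leave unreadable from compound 2 to compound 3 therefore carry no readable size, since (the limit of > 200000 nM in this assay, at which 3 of the 3 values shown sit). Compound 4 `CC(=O)C(C)CCCCc1cc(O)c(C)c(=O)o1` differs from compound 3 by 2-acetylpropyl in place of isopropyl on a saturated chain carbon, three bonds along the chain from an aromatic carbon. Among the compounds with values here, no measured step resembles this change, and the three values give no direction. Compound 4 is expected to remain at the limit, with the step that the limit leaves unreadable from compound 3 to compound 4 reflecting only that expectation. The estimate for compound 4 in this assay is 250000 nM, between 60000 nM and 1000000 nM.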

Compound 4, half-maximal inhibitory concentration: > 200000 nM
Compound 4 gave a limit, no number; the forecaster's own chance of this, stated with the estimate: 80%; the middle value is on the limit's open side.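

Compounds 1, 2, 3 and 4 all stay at a limit in this assay, so no step to compound 4 can be read: the limit of > 200000 nM in this assay, at which 4 of the 4 values shown sit.

From the compounds shown here alone, whether any side chain on the shared core gives a measurable value in this assay remains open.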